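A few compounds are considered here, and "the series" means these few. Any claim that something is new, unique, unknown or untested is made for them only; others in the source may bear on it.

In an ADME assay on HeLa cells (Homo sapiens) for cytotoxicity, read by resazurin assay, with a stated time of 2 days (a lower number here means a stronger inhibitor, a higher number a weaker inhibitor), compound 1 `Cn1c([N+](=O)[O-])cnc1/C=C/c1cccc(I)c1` gives 31600 nM. Compound 2 `Cn1c([N+](=O)[O-])cnc1/C=C/c1cccc(F)c1` gives > 100000 nM, and this is a limit of the assay, not a number. Compound 2 therefore sits at the limit (the limit of > 100000 nM in this assay, at which 1 of the 2 values shown sits), so its true position in this assay is not fixed.

The change to compound 3 `COc1cccc(/C=C/c2ncc([N+](=O)[O-])n2C)c1` is methoxy in place of fluoro on an aromatic carbon, meta to a large group. Going by the values given here, only one measured step bears on this change: an at least 3.1-fold higher number from compound 1 to compound 2 (0.50 log units; beyond the scatter), with fluoro in place of iodo on an aromatic carbon. That step lies beyond the scatter and is at least modest, which shows that the group at this place can matter in this assay. It is a single step, however, and it involves a different incoming group, so it gives the direction only loosely. Among the compounds with values here, compound 1, at 31600 nM, is the only real number to lean on, and compound 3 is expected to fall towards it without clearly reaching it. The expected change is an at least 1.6-fold lower number from compound 2 to compound 3 (0.22 log units; that floor lies within the scatter), a modest move towards a lower number. For compound 3 the estimated value is 60000 nM, with an expected range from 25000 nM to 100000 nM.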

Compound 3, half-maximal inhibitory concentration: > 100000 nM
Compound 3 gave a limit, no number (the forecaster's own chance of this, stated with the estimate: 45%); middle value at least 1.6-fold (0.22 log units) away from the limit.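

In this assay, methoxy in place of iodo gives an at least 3.1-fold higher number from compound 1 to compound 3 (0.50 log units; beyond the scatter). Going by these compounds alone, a second incoming group thus moves away from compound 1 in the same direction as fluoro did, so the earlier step was not particular to fluoro, and compound 1 remains the only one of the three compounds with a real number. Compound 3 gives a limit and not a number, and it sits at the same limit as compound 2: the limit of > 100000 nM in this assay, at which 2 of the 3 values shown sit.

The step between compound 2 and compound 3 cannot be read, so methoxy and fluoro cannot be placed in any order on this aromatic carbon, meta to a large group, and nothing can be said about the extra heavy atom or the hydrogen-bond acceptor that methoxy brings. The compounds shown leave open where compound 2 and compound 3 truly stand in this assay, and whether the real number of compound 1 belongs to iodo alone or would also appear with bromo, chloro, an amine or a carboxylic acid at this place.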